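The source may hold more compounds than are shown below. What is called first, only, known or untested is meant among the compounds shown, and "the series" means these compounds.

Measured so far: compound 1 `CCCCc1cnc(C(CC)Cc2ccc(-c3ccccc3C(=O)O)cc2)[nH]1` gives 2720 nM; compound 2 `O=C(O)c1ccccc1-c1ccc(CCc2ncc(CC3CCCCC3)[nH]2)cc1` gives 41 nM; compound 3 `CCCCc1cnc(C(C)Cc2ccc(-c3ccccc3C(=O)O)cc2)[nH]1` gives 2760 nM.

All three were tested in an in vitro functional assay on cells for agonist activity at Bombesin receptor subtype-3 (Homo sapiens), read by luminescence and calcium flux; on this read-out higher numbers stand for an effect only at larger amounts of compound and lower numbers for an effect already at smaller amounts. Compound 2 stands lowest of the three, with compound 1 and compound 3 both far higher, well beyond the scatter. Going by the values given here, the only measured step, a 1.0-fold higher number from compound 1 to compound 3 (0.01 log units; within the scatter), concerns a hydrogen-for-methyl swap on the chain and tells nothing about the ring that changes here. Compound 4 `O=C(O)c1ccccc1-c1ccc(CCc2ncc(Cc3ccc(F)cc3)[nH]2)cc1` differs from compound 2 by 4-fluorophenyl in place of cyclohexyl on a saturated chain carbon bound to an aromatic carbon. Among the compounds with values here, no measured step bears on this exchange, so the expectation rests on compound 2 alone, with wide uncertainty. Compound 4 is expected to lose some ground, a 2.9-fold higher number from compound 2 to compound 4 (0.47 log units; beyond the scatter), giving an estimated 120 nM within a range of 30 nM to 500 nM.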

Compound 4, half-maximal effective concentration: 1600 nM
Beside the measured number, compound 4's estimate is 13-fold (1.12 log units) below it, and the stated range ends below it.
By their numbers in this assay, from the lowest: compound 2; then compounds 4, 1 and 3 (each within the scatter of the next).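

The exchange of cyclohexyl for 4-fluorophenyl on this saturated chain carbon is costly, a 39-fold higher number from compound 2 to compound 4 (1.59 log units; beyond the scatter), so this position does not tolerate every six-membered ring equally. Going by these compounds alone, the only earlier step, a 1.0-fold higher number from compound 1 to compound 3 (0.01 log units; within the scatter), concerned another part of the molecule and gave no view of this one. No measurement at hand explains the size of this loss.

On these data alone, it remains open whether the loss follows the aromatic ring or its fluorine, which an unsubstituted phenyl group could help separate. How a longer alkyl chain or an amine would fare at this position is also unknown.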